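Methylsulfonyl replacement in the series: expectation for compound 4

The compounds below may be only part of what the source reports. "The series", "measured", "known", "first", "only" and "open" are said of these compounds alone.

Compound 1 (`CC(C)c1n[nH]c2c(NCc3ccc(-c4ccccn4)cc3)nc(S(C)(=O)=O)nc12`) gives 460 nM in a functional assay on MCF7 cells (Homo sapiens) for cytotoxicity, read by fluorescence, with a stated time of 72 h (a higher number here means a weaker inhibitor, a lower number a stronger inhibitor), and stands within the scatter of compound 3 (`CC(C)c1n[nH]c2c(NCc3ccc(-c4ccccn4)cc3)nc(N[C@@H]3CCCC[C@H]3N)nc12`) at 295 nM while lying clearly above compound 2 (`CC(C)c1n[nH]c2c(NCc3ccc(-c4ccccn4)cc3)nc(NCCN)nc12`) at 62 nM in the same read-out. Compound 4 (`CC(C)c1n[nH]c2c(NCc3ccc(-c4ccccn4)cc3)nc(NCC(N)CO)nc12`) changes the same place between two ring nitrogen atoms (a group of 6 heavy atoms (3 carbon, 2 nitrogen, 1 oxygen; no ring) in place of a group of 4 heavy atoms (1 carbon, 2 oxygen, 1 sulfur; no ring), on an aromatic carbon). Two measured steps make this replacement: a 7.4-fold lower number from compound 1 to compound 2 (0.87 log units; beyond the scatter) with an entering group without a ring and a 1.6-fold lower number from compound 1 to compound 3 (0.19 log units; within the scatter) with a cyclohexyl group, and a 4.8-fold higher number from compound 2 to compound 3 (0.68 log units; beyond the scatter) separates them. The entering group of compound 4 has no ring, so the nearer guide is compound 2 with a 7.4-fold lower number from compound 1 to compound 2 (0.87 log units; beyond the scatter) as its step. The estimated step in this assay is a 4.6-fold lower number from compound 1 to compound 4 (0.66 log units; beyond the scatter) and is expected to point the same way, beyond the scatter. Compound 4 is estimated at 100 nM (40 nM to 280 nM).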

Compound 4, half-maximal inhibitory concentration: 310 nM
For compound 4 the middle estimate is 3.1-fold (0.49 log units) below the measured one; measured number outside the range, above it.
By their numbers in this assay, from the lowest: compound 2; then compounds 3, 4 and 1 (each within the scatter of the next).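

In this assay, hydroxymethyl on the saturated chain carbon of compound 2 removes most of the advantage of that chain (a 5.0-fold higher number from compound 2 to compound 4 (0.70 log units; beyond the scatter)). The result is level with the methylsulfonyl starting point (a 1.5-fold lower number from compound 1 to compound 4 (0.17 log units; within the scatter)) and with the 2-aminocyclohexyl analogue (a 1.1-fold higher number from compound 3 to compound 4 (0.02 log units; within the scatter)). An entering group without a ring is therefore not enough at this position: of the groups shown, only the unsubstituted 2-aminoethyl chain of compound 2 stands apart.

Still open, on these data alone, is whether a methyl group on that chain carbon, or a longer 3-aminopropyl chain, would keep the number of compound 2. No supporting data explain the loss seen with hydroxymethyl.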